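Swapping a pyrazole for a substituted phenyl on the aniline nitrogen

This account rests on a few compounds, and the source may have more. Where it says the series, first, only, none or still open, it means among the compounds named here.

Three compounds share one core and differ in the group carried on a nitrogen on an aromatic ring. Compound 1 `COc1ncc(-c2ccc3ncnc(Nc4ccc(OCCO)c(F)c4)c3c2)cc1NS(=O)(=O)c1ccc(F)cc1F` gives 4820 nM in a functional assay on MCF7 cells (Homo sapiens) for antiproliferative activity, read by sulforhodamine B assay, with a stated time of 72 h; a lower number here means a stronger inhibitor, a higher number a weaker inhibitor. Compound 2 `COc1ncc(-c2ccc3ncnc(Nc4cnn(CC(=O)O)c4)c3c2)cc1NS(=O)(=O)c1ccc(F)cc1F` gives 700 nM in this assay, and compound 3 `COC(=O)Cn1cc(Nc2ncnc3ccc(-c4cnc(OC)c(NS(=O)(=O)c5ccc(F)cc5F)c4)cc23)cn1` gives 670 nM in this assay, the lowest of the three numbers, though the gap to compound 2 lies within the scatter, a 1.0-fold lower number from compound 2 to compound 3 (0.02 log units; within the scatter). The move from the 3-fluoro-4-(2-hydroxyethoxy)phenyl group to a pyrazole brought a clear gain: a 6.9-fold lower number from compound 1 to compound 2 (0.84 log units; beyond the scatter) and a 7.2-fold lower number from compound 1 to compound 3 (0.86 log units; beyond the scatter).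

Compound 4 `COc1cc(Nc2ncnc3ccc(-c4cnc(OC)c(NS(=O)(=O)c5ccc(F)cc5F)c4)cc23)ccc1OCCO` carries the change (4-(2-hydroxyethoxy)-3-methoxyphenyl in place of 1-((methoxycarbonyl)methyl)-1H-pyrazol-4-yl on a nitrogen on an aromatic ring). This largely reverses the step from compound 1 to compound 3, returning to a phenyl bearing a 2-hydroxyethoxy chain, now with a methoxy rather than a fluoro group. Since that earlier step was a 7.2-fold lower number from compound 1 to compound 3 (0.86 log units; beyond the scatter), compound 4 is expected to land near compound 1, a step of a 5.2-fold higher number from compound 3 to compound 4 (0.72 log units; beyond the scatter) in this assay. Compound 4 is therefore estimated at 3500 nM, within a range of 1200 nM to 10000 nM.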

Compound 4, half-maximal inhibitory concentration: 2260 nM
For compound 4 the middle estimate is 1.5-fold (0.19 log units) above the measured one; measured number inside the range.
By their numbers in this assay, from the lowest: compounds 3 and 2 (each within the scatter of the next); then compound 4; then compound 1.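

The phenyl group of compound 4 stays on the weaker side of both pyrazoles in this assay (a 3.4-fold higher number from compound 3 to compound 4 (0.53 log units; beyond the scatter); a 3.2-fold higher number from compound 2 to compound 4 (0.51 log units; beyond the scatter)), so the pyrazoles' advantage now holds against two phenyl groups rather than one. The phenyl group is also sensitive to a single small swap: methoxy in place of fluoro on an aromatic carbon gives a step beyond the scatter (a 2.1-fold lower number from compound 1 to compound 4 (0.33 log units; beyond the scatter)), closing part of the gap to the pyrazoles without removing it. Nothing measured here explains any of these steps.

Still open, from the compounds shown here alone, is whether an amine or a primary amide at the end of the pyrazole side chain would give numbers like those of compound 2 and compound 3. Also open, going by these compounds, is whether chloro or plain hydrogen in place of the methoxy of compound 4 would shift its number further.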